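A Fluoro Substituent on the Carboxyphenyl Ether Tail

The compounds below may be only part of what the source reports. "The series", "measured", "known", "first", "only" and "open" are said of these compounds alone.

Compound 1 `Cc1c(OCCCCOc2ccccc2C(=O)O)ccc(C(=O)CC(C)C)c1O`: "not determined" (no result reported)
Compound 2 `Cc1c(OCCCCOc2ccc(C(=O)O)cc2)ccc(C(=O)CC(C)C)c1O`: 2720 nM
Compound 3 `Cc1c(OCCCCOc2ccc(C(=O)O)cc2)ccc(C(=O)CC2CCCC2)c1O`: > 10000 nM

Among the compounds with values here, in an assay on HEK293 cells for positive allosteric modulation of metabotropic glutamate receptor 3 (Rattus norvegicus), read by thallium flux, with a stated time of 2.5 min (on this read-out higher numbers stand for an effect only at larger amounts of compound and lower numbers for an effect already at smaller amounts), compound 2 gives 2720 nM, the only single number among the three. Compound 1 has no result. The value of compound 3 is a limit of this assay, not a number. Between them stands an at least 3.6-fold higher number from compound 2 to compound 3 (0.56 log units; beyond the scatter), a change at the saturated chain carbon bound to the carbonyl carbon; it is framed by the limit of > 10000 nM in this assay, at which 1 of the 3 values shown sits.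

Compound 4 `Cc1c(OCCCCOc2ccc(C(=O)O)cc2F)ccc(C(=O)CC(C)C)c1O` differs from compound 2 by fluoro in place of hydrogen on an aromatic carbon. Within the data shown here, no measured step touches this aromatic carbon, so the only guide is the unchanged value of compound 2. The step is therefore expected to stay within the scatter, with a 1.1-fold lower number from compound 2 to compound 4 (0.04 log units; within the scatter) as the estimate. Compound 4 is estimated at 2500 nM, between 800 nM and 8000 nM.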

Compound 4, half-maximal effective concentration: 1420 nM
Beside the measured number, compound 4's estimate is 1.8-fold (0.25 log units) above it; measured number inside the range.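

In this assay, going from 4-carboxyphenyl to 4-carboxy-2-fluorophenyl gives a 1.9-fold lower number from compound 2 to compound 4 (0.28 log units; within the scatter), so fluoro on this aromatic carbon, ortho to a large group and meta to a carboxy group, brings no change that can be told from the scatter. Unlike the cyclopentyl change on the chain, this change leaves a single number and not a limit: the limit of > 10000 nM in this assay, at which 1 of the 4 values shown sits.

From the compounds shown here alone, whether chloro, methoxy or a nitrile on this same carbon would move the number beyond the scatter stays open. So does the effect of an amine in place of the carboxy group.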